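This account rests on a few compounds, and the source may have more. Where it says the series, first, only, none or still open, it means among the compounds named here.

Measured compounds:
compound 1, `C[Se]/C(=N\C(=O)c1ccc(Cl)nc1)NC(=O)c1ccc(Cl)nc1`, 9140 nM;
compound 2, `C[Se]/C(=N\C(=O)c1ccccc1)NC(=O)c1ccccc1`, 2500 nM.

In a functional assay on PC-3 cells (Homo sapiens) for cytotoxicity, read by MTT assay (a lower number here means a stronger inhibitor, a higher number a weaker inhibitor), compound 2 gives 2500 nM, the lower of the two numbers recorded so far. Compound 1 gives 9140 nM in this assay, a higher number, and the gap between the two lies beyond the usual scatter of repeated measurements. The account now turns to compound 3, `CC(C)[Se]/C(=N\C(=O)c1ccccc1)NC(=O)c1ccccc1`, which has not yet been measured. It differs from compound 2 in a single place: isopropyl in place of methyl on a selenium. Among the compounds with values here, no measured pair in this set shows what such a change does, so there is no step to lean on. The expectation is therefore a modest step from compound 2 to compound 3, no change at the digits printed from compound 2 to compound 3 (within the scatter), in no firm direction and probably not beyond the scatter. Compound 3 is estimated to give 2500 nM in this assay, within a range from 800 nM to 8000 nM.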

Compound 3, half-maximal inhibitory concentration: > 10000 nM
Compound 3: no number, only a limit; the forecaster's own chance of this, stated with the estimate: 5%; middle value at least 4.0-fold (0.60 log units) away from the limit.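

Isopropyl in place of methyl on a selenium gives an at least 4.0-fold higher number from compound 2 to compound 3 (0.60 log units; beyond the scatter) in this assay, the first sign that the group on this selenium bears on the read-out. Compound 1 and compound 2 both carry methyl there, so they could show nothing of the kind. Compound 3 has a limit of the assay rather than a number, which leaves the true size of the step unknown: the limit of > 10000 nM in this assay, at which 1 of the 3 values shown sits.

The compounds shown do not tell whether branching itself or simply the larger group goes with the weaker reading, and ethyl or a longer straight chain on the selenium would separate the two. Also open, going by these compounds, are how an amine or a carboxylic acid at the end of such a chain would read in this assay, and whether the same change has a similar effect on the core of compound 1.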